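Imine chain length: from compound 1 toward compound 4

A few compounds are considered here, and "the series" means these few. Any claim that something is new, unique, unknown or untested is made for them only; others in the source may bear on it.

Going by the values given here, compound 1 `C/C(=N\CC(C)C)c1c(O)c2ccccc2oc1=O` is the one member with a number: in an assay on isolated protein for inhibition of myosin-2 (Bos taurus), read by spectrophotometry, with a stated time of 24 min (on this read-out lower numbers stand for stronger inhibition and higher numbers for weaker inhibition), compound 1 gives 34000 nM. The two other compounds stop at a limit. Compound 2 `C/C(=N\CC1CCCCC1)c1c(O)c2ccccc2[nH]c1=O` gives in this assay the limit >= 100000 nM. Compound 3 `CCCC/N=C(\C)c1c(O)c2ccccc2[nH]c1=O` gives in this assay the limit >= 100000 nM. Among the compounds with values here, the only recorded step, a step that the two limits leave unreadable from compound 2 to compound 3, is hidden by the limit of >= 100000 nM in this assay, at which 2 of the 3 values shown sit. Compound 4 `CCCCCC/N=C(\C)c1c(O)c2ccccc2oc1=O` differs from compound 1 by pentyl in place of isopropyl on a saturated chain carbon bound to a double-bonded nitrogen. Within the data shown here, no measured step bears on this change, and the one step recorded is unreadable, so no direction beyond the scatter can be drawn. Compound 4 is therefore expected near compound 1, with a 1.1-fold lower number from compound 1 to compound 4 (0.05 log units; within the scatter) taken as an estimate of no change. Compound 4 is estimated at 30000 nM, between 8000 nM and 100000 nM.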

Compound 4, half-maximal inhibitory concentration: 2900 nM
The estimate for compound 4 lay 10-fold (1.01 log units) above the measured number, and the stated range ends above it.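

In this assay, going by these compounds alone, pentyl in place of isopropyl on a saturated chain carbon bound to a double-bonded nitrogen gives a 12-fold lower number from compound 1 to compound 4 (1.07 log units; beyond the scatter) and is the first readable step at this position. The position therefore responds to the chain on the core of compound 1. Compound 2 and compound 3 could not show this, as both stand at a limit and their step cannot be read: the limit of >= 100000 nM in this assay, at which 2 of the 4 values shown sit.

This single step does not separate added length from loss of the branch. As far as these compounds go, whether a longer chain such as octyl, or a chain ending in an amine, keeps the lower number stays open.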